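This account rests on a few compounds, and the source may have more. Where it says the series, first, only, none or still open, it means among the compounds named here.

Working notes on the aryl hydrazone series

Three compounds of this series share one core and differ only in the aryl group on the carbon with a double bond to nitrogen. Compound 1 `COc1ccc(OC)c(/C=N/NC(=O)Nc2ccc(Oc3ccnc(-c4nncn4CCN(C)C)c3)c(F)c2)c1` carries a 2,5-dimethoxyphenyl group there and in a functional assay on HT-29 cells (Homo sapiens) for cytotoxicity, read by MTT assay, with a stated time of 72 h (on this read-out lower numbers stand for stronger inhibition and higher numbers for weaker inhibition), compound 1 gives 2070 nM. Compound 2 `CN(C)CCn1cnnc1-c1cc(Oc2ccc(NC(=O)N/N=C/c3ccccc3)cc2F)ccn1` carries a plain phenyl group, and in this assay compound 2 gives 1120 nM. Compound 3 `CN(C)CCn1cnnc1-c1cc(Oc2ccc(NC(=O)N/N=C/c3ccc(O)c(O)c3)cc2F)ccn1` carries a 3,4-dihydroxyphenyl group; in this assay compound 3 gives 1890 nM, the second highest of the three numbers, nearest to compound 1 and furthest from compound 2.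

All three steps stay within the scatter: a 1.8-fold lower number from compound 1 to compound 2 (0.27 log units; within the scatter), a 1.1-fold lower number from compound 1 to compound 3 (0.04 log units; within the scatter) and a 1.7-fold higher number from compound 2 to compound 3 (0.23 log units; within the scatter). The aryl group has so far moved the read-out little.

Compound 4 `CN(C)CCn1cnnc1-c1cc(Oc2ccc(NC(=O)N/N=C/c3cccc(Br)c3)cc2F)ccn1` is the next member. Relative to compound 3 the change is 3-bromophenyl in place of 3,4-dihydroxyphenyl on a carbon with a double bond to nitrogen. For the measured compounds named here, no measured step covers a halogen on this ring; the nearest comparisons are the phenyl and dimethoxyphenyl steps above, which bear on it only loosely. Given that compound 2 gives 1120 nM and compound 3 gives 1890 nM, the step expected in this assay is a 1.5-fold lower number from compound 3 to compound 4 (0.16 log units; within the scatter), a small move toward a lower number. Compound 4 is therefore estimated at 1300 nM, with a range from 500 nM to 3500 nM.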

Compound 4, half-maximal inhibitory concentration: 380 nM
Beside the measured number, compound 4's estimate is 3.4-fold (0.53 log units) above it; the measured number lies below the stated range.
By their numbers in this assay, from the lowest: compound 4; then compounds 2, 3 and 1 (each within the scatter of the next).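

In this assay, for the compounds shown here, the aryl group on the carbon with a double bond to nitrogen now moves the read-out beyond the scatter: the single change of bromo in place of hydrogen on an aromatic carbon gives a 2.9-fold lower number from compound 2 to compound 4 (0.47 log units; beyond the scatter) and the larger replacements give a 5.0-fold lower number from compound 3 to compound 4 (0.70 log units; beyond the scatter) and a 5.4-fold lower number from compound 1 to compound 4 (0.74 log units; beyond the scatter). Compound 4 thus stands apart with the lowest number of the four, while compounds 1, 2 and 3 remain within the scatter of one another, so the plain phenyl, 3,4-dihydroxyphenyl and 2,5-dimethoxyphenyl groups cannot be told apart here and only the 3-bromophenyl group separates from them. No measurement at hand accounts for this separation.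

Bromo appears here only in the 3-bromophenyl group of compound 4, so it remains open whether the lower number is particular to bromo or would also follow from a chloro, methyl or amino group in its place. Also open, as far as these compounds go, is whether this step would hold on the dimethoxyphenyl or dihydroxyphenyl rings, or with a different chain in place of the dimethylaminoethyl chain on the shared core.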